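The source may hold more compounds than are shown below. What is called first, only, known or untested is meant among the compounds shown, and "the series" means these compounds.

Measured so far in an assay on isolated protein for inhibition of phosphatidylinositol 4,5-bisphosphate 3-kinase catalytic subunit beta isoform (Homo sapiens), read by 33P incorporation, with a stated time of 60 min; on this read-out higher numbers stand for weaker inhibition and lower numbers for stronger inhibition:

Compound 1 `Cc1ccc([N+](=O)[O-])cc1S(=O)(=O)N(C)/N=C/c1cnn2ccccc12` gives only a limit, > 10000 nM.
Compound 2 `COc1ccn2ncc(/C=N/N(C)S(=O)(=O)c3cc([N+](=O)[O-])ccc3C)c2c1` gives only a limit, > 1000 nM.
Compound 3 `C#Cc1ccn2ncc(/C=N/N(C)S(=O)(=O)c3cc([N+](=O)[O-])ccc3C)c2c1` gives 30 nM.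

For the measured compounds named here, compound 3 thus carries the only actual number among the three values; the other two are limits of the assay. Compound 4 `Cc1ccc([N+](=O)[O-])cc1S(=O)(=O)N(C)/N=C/c1cnn2ccc(C(=O)N(C)C)cc12` differs from compound 3 in one place: dimethylcarbamoyl in place of ethynyl on an aromatic carbon. Going by the values given here, two measured steps bear on this position. Adding ethynyl to the bare core gave an at least 330-fold lower number from compound 1 to compound 3 (2.52 log units; beyond the scatter), and exchanging methoxy for ethynyl gave an at least 33-fold lower number from compound 2 to compound 3 (1.52 log units; beyond the scatter). Both show that the group at this position matters greatly, yet neither tells how dimethylcarbamoyl compares with ethynyl. Losing the ethynyl is therefore expected to weaken inhibition, and compound 4 is estimated at 300 nM, between 50 nM and 3000 nM, a step of a 10-fold higher number from compound 3 to compound 4 (1.00 log units; beyond the scatter) in this assay.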

Compound 4, half-maximal inhibitory concentration: > 1000 nM
Compound 4 ended at the assay's limit (the forecaster's own chance of this, stated with the estimate: 25%); middle value at least 3.3-fold (0.52 log units) away from the limit.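

Exchanging ethynyl for dimethylcarbamoyl gives an at least 33-fold higher number from compound 3 to compound 4 (1.52 log units; beyond the scatter). Methoxy was therefore not an isolated failure: a second, quite different group at this position also falls far short of ethynyl, and this one brings a carbonyl and a hydrogen-bond acceptor. The steps among compound 1, compound 2 and compound 4 cannot be read, as each value is only a limit of the assay, so these three cannot be ranked.

From the compounds shown here alone, what in ethynyl supports inhibition remains open. A nitrile or a longer alkyne chain at this position could begin to answer that.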